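From 4-nitrophenyl to 2-fluorophenyl on the shared core

The compounds below may be only part of what the source reports. "The series", "measured", "known", "first", "only" and "open" are said of these compounds alone.

Compound 1 `Fc1ccccc1N1CCN(CCN2CCN(c3ccccc3F)CC2)CC1`: 40000 nM
Compound 2 `O=[N+]([O-])c1ccc(N2CCN(CCN3CCN(c4ccc(F)cc4)CC3)CC2)cc1`: 77900 nM

In a functional assay on LNCaP cells (Homo sapiens) for cytotoxicity, read by MTT assay, with a stated time of 24 h (on this read-out lower numbers stand for an effect already at smaller amounts and higher numbers for an effect only at larger amounts of compound), compound 2 gives 77900 nM, within the scatter of compound 1 at 40000 nM, so the two cannot be told apart. Compound 3 `Fc1ccc(N2CCN(CCN3CCN(c4ccccc4F)CC3)CC2)cc1` differs from compound 2 in one place: 2-fluorophenyl in place of 4-nitrophenyl on an amine nitrogen in a ring. It carries 2-fluorophenyl in place of 4-nitrophenyl on an amine nitrogen in a ring. Among the compounds with values here, no measured step shows what this change does in this assay. Within the data shown here, the only guide is compound 1, which also bears 2-fluorophenyl and gives 40000 nM. A step within the scatter, towards a lower number, is expected: the estimated 1.6-fold lower number from compound 2 to compound 3 (0.19 log units; within the scatter). For compound 3 the expected value is 50000 nM, with an estimated range of 20000 nM to 120000 nM.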

Compound 3, half-maximal effective concentration: 68000 nM
Beside the measured number, compound 3's estimate is 1.4-fold (0.13 log units) below it, within the range that was stated.
By their numbers in this assay, from the lowest: compounds 1, 3 and 2 (each within the scatter of the next).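

In this assay, putting 2-fluorophenyl in place of 4-nitrophenyl on this amine nitrogen in a ring gives (a 1.1-fold lower number from compound 2 to compound 3 (0.06 log units; within the scatter)), so exchanging these two groups here produces no step beyond the scatter. Putting 4-fluorophenyl in place of 2-fluorophenyl on an amine nitrogen in a ring gives (a 1.7-fold higher number from compound 1 to compound 3 (0.23 log units; within the scatter)), so compound 1, compound 2 and compound 3 cannot be told apart. Nothing measured offers a reason for these results. Still open, going by these compounds, is whether an amine or a carboxylic acid in place of these aryl groups would give a step beyond the scatter.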